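Aryl amine swap on a quinazoline-type cytotoxicity series

The source may report more compounds than this note shows. Statements on the series, on what has been measured and on what is new or still open speak of the compounds shown alone.

Measured compounds:
compound 1 `CCS(=O)(=O)Nc1cc(-c2ccc3ncnc(Nc4ccc(F)cc4F)c3c2)cnc1OC`: 2490 nM
compound 2 `CCS(=O)(=O)Nc1cc(-c2ccc3ncnc(Nc4ccc(OC)c(Cl)c4)c3c2)cnc1OC`: 2810 nM

In a functional assay on SK-HEP1 cells (Homo sapiens) for cytotoxicity, read by sulforhodamine B assay, with a stated time of 72 h (a higher number here means a weaker inhibitor, a lower number a stronger inhibitor), compound 2 gives 2810 nM, the higher of the two numbers, but the step of a 1.1-fold higher number from compound 1 to compound 2 (0.05 log units; within the scatter) is within the scatter, so the two compounds cannot be told apart. Compound 3 `CCS(=O)(=O)Nc1cc(-c2ccc3ncnc(Nc4ccc(C(=O)OC)c(OC)c4)c3c2)cnc1OC` differs from compound 2 by 3-methoxy-4-(methoxycarbonyl)phenyl in place of 3-chloro-4-methoxyphenyl on a nitrogen on an aromatic ring. For the measured compounds named here, no measured step covers this change; the only one available, a 1.1-fold higher number from compound 1 to compound 2 (0.05 log units; within the scatter), swapped one aryl group for another without moving the number. No step beyond the scatter is therefore expected, and a 1.1-fold higher number from compound 2 to compound 3 (0.03 log units; within the scatter) is the estimate. Compound 3 is expected to give 3000 nM, between 1000 nM and 9000 nM.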

Compound 3, half-maximal inhibitory concentration: 830 nM
Compound 3: the middle estimate sits 3.6-fold (0.56 log units) above what was measured, and the stated range ends above it.
By their numbers in this assay, from the lowest: compound 3; then compounds 1 and 2 (each within the scatter of the next).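

The aryl group on this nitrogen can move the number in this assay: 3-methoxy-4-(methoxycarbonyl)phenyl gives a step beyond the scatter against both earlier groups (a 3.4-fold lower number from compound 2 to compound 3 (0.53 log units; beyond the scatter)) and (a 3.0-fold lower number from compound 1 to compound 3 (0.48 log units; beyond the scatter)). The earlier match between compound 1 and compound 2 therefore did not mean that every aryl swap here leaves the number unchanged. Nothing available gives a reason for this step.

The compounds shown leave open whether the methoxycarbonyl or the methoxy carries the step. They also leave open how a carboxylic acid or an amide in place of the methyl ester would read.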